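From Compound 3 to Compound 4 at the Assay Limit

The compounds below may be only part of what the source reports. "The series", "measured", "known", "first", "only" and "open" are said of these compounds alone.

Measured in a functional assay on DU-145 cells (Homo sapiens) for antiproliferative activity, read by MTT assay, with a stated time of 48 h; on this read-out lower numbers stand for stronger inhibition and higher numbers for weaker inhibition:
Compound 1 `C/C(=C\CC/C(C)=C/CC[C@@H]1[C@@]2(C)CCC(=O)C(C)(C)[C@H]2CC[C@@]1(C)O)CC/C=C(\C)C(=O)OCc1cn(-c2ccccc2C(F)(F)F)nn1`: > 150000 nM
Compound 2 `C/C(=C\CC/C(C)=C/CC[C@@H]1[C@@]2(C)CCC(=O)C(C)(C)[C@H]2CC[C@@]1(C)O)CC/C=C(\C)C(=O)OCc1cn(-c2ccccc2Br)nn1`: > 150000 nM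
Compound 3 `C/C(=C\CC/C(C)=C/CC[C@@H]1[C@@]2(C)CCC(=O)C(C)(C)[C@H]2CC[C@@]1(C)O)CC/C=C(\C)C(=O)OCc1cn(-c2ccc(F)c(Cl)c2)nn1`: > 150000 nM

Each of these entries is a limit of the assay and not a number. Compound 3 has only the limit > 150000 nM. It shares its place with the other two compounds, as the limit of > 150000 nM in this assay, at which 3 of the 3 values shown sit, shows.

Compound 4 `C/C(=C\CC/C(C)=C/CC[C@@H]1[C@@]2(C)CCC(=O)C(C)(C)[C@H]2CC[C@@]1(C)O)CC/C=C(\C)C(=O)OCc1cn(-c2cccc(C)c2)nn1` changes one group of compound 3: 3-methylphenyl in place of 3-chloro-4-fluorophenyl on an aromatic nitrogen. In words, 3-methylphenyl stands in place of 3-chloro-4-fluorophenyl on an aromatic nitrogen.

Within the data shown here, three measured steps bear on this change, each altering the same aromatic group: a step that the two limits leave unreadable from compound 1 to compound 2, a step that the two limits leave unreadable from compound 1 to compound 3 and a step that the two limits leave unreadable from compound 2 to compound 3. None has a readable size, so they offer no size or direction to carry over. Compound 4 is therefore expected to stay near this limit, with the estimated change being a step that the limit leaves unreadable from compound 3 to compound 4 and no direction expected. Compound 4 is estimated at 200000 nM, with an expected range from 70000 nM to 500000 nM.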

Compound 4, half-maximal inhibitory concentration: 137000 nM
For compound 4 the middle estimate is 1.5-fold (0.16 log units) above the measured one; the range from low to high includes it.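

In this assay, among these compounds, compound 4 is the first compound here to give a number and not a limit: 137000 nM. This makes the comparison at this aromatic group readable for the first time, since the steps among the three earlier compounds cannot be read, but the new steps are only floors, an at least 1.0-fold lower number from compound 3 to compound 4 (0.03 log units; that floor lies within the scatter), an at least 1.0-fold lower number from compound 2 to compound 4 (0.03 log units; that floor lies within the scatter) and an at least 1.0-fold lower number from compound 1 to compound 4 (0.03 log units; that floor lies within the scatter), so 3-methylphenyl is not shown to differ from the groups it replaces. Most of the series still sits at the edge of what the assay can report: the limit of > 150000 nM in this assay, at which 3 of the 4 values shown sit.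

From the compounds shown here alone, what stays open is whether any aromatic group on this nitrogen can give a number clearly lower than that of compound 4. The compounds shown also do not tell how an amine or a carboxylic acid in place of the methyl of compound 4 would read.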